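This account rests on a few compounds, and the source may have more. Where it says the series, first, only, none or still open, it means among the compounds named here.

In a functional assay on MV cells (Homo sapiens) for inhibition, read by sulforhodamine B assay (a lower number here means a stronger inhibitor, a higher number a weaker inhibitor), compound 3, whose structure is `C#CC(=O)N1C(c2ccccc2)SC[C@@H]1C(=O)OCC`, gives 400 nM. That is the lowest of the three numbers recorded, but its nearest neighbour is compound 1, `C#CC(=O)N1C(C(C)CCC)SC[C@@H]1C(=O)OCC`, which gives 500 nM in this assay, and the difference a 1.3-fold lower number from compound 1 to compound 3 (0.10 log units; within the scatter) lies within the scatter, so the two cannot be ranked. The only clear separation is from compound 2, `C#CC(=O)N1C(c2ccc(C#N)cc2)SC[C@@H]1C(=O)OCC`, which gives 2400 nM in this assay; the step of a 6.0-fold lower number from compound 2 to compound 3 (0.78 log units; beyond the scatter) is beyond the scatter.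

Compound 4, `C#CC(=O)N1C(CCCCC)SC[C@@H]1C(=O)OCC`, has not yet been measured. It differs from compound 3 in one place: pentyl in place of phenyl on a saturated ring carbon. Among the compounds with values here, the step that bears on this is the one from compound 1 to compound 3, where a phenyl replaced a 1-methylbutyl on the same saturated ring carbon and the number hardly moved, a 1.3-fold lower number from compound 1 to compound 3 (0.10 log units; within the scatter). Compound 4 reverses that exchange with a different alkyl chain, pentyl, so a saturated chain again sits where the phenyl was. On that basis no step beyond the scatter is expected in this assay, a 1.1-fold higher number from compound 3 to compound 4 (0.05 log units; within the scatter). Compound 4 is therefore estimated at 450 nM in this assay, with a range from 200 nM to 1000 nM. The step from compound 2 to compound 3 does not touch this change.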

Compound 4, half-maximal inhibitory concentration: 2000 nM
Estimate against measurement, compound 4: 4.4-fold (0.65 log units) below; measured number outside the range, above it.
By their numbers in this assay, from the lowest: compounds 3 and 1 (each within the scatter of the next); then compounds 4 and 2 (each within the scatter of the next).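

In this assay, this position on the saturated ring carbon, next to the ring nitrogen and the ring sulfur, turns out to respond to which alkyl chain it carries, and not merely to whether the group there is an alkyl chain or an aromatic ring. Exchanging 1-methylbutyl for pentyl gives a 4.0-fold higher number from compound 1 to compound 4 (0.60 log units; beyond the scatter), and this step between two saturated chains is beyond the scatter. Exchanging phenyl for pentyl gives a 5.0-fold higher number from compound 3 to compound 4 (0.70 log units; beyond the scatter), so the match between phenyl and 1-methylbutyl seen earlier does not extend to pentyl, and no explanation for the separation of pentyl from the other two groups is available from any supporting data.

The compounds shown leave open whether the methyl branch of 1-methylbutyl is the feature that separates it from pentyl, a question that a group such as 1-methylpropyl, isopropyl or a longer branched chain could help to address. They also leave open how a shorter or longer unbranched chain, a cyclohexyl ring or a chain ending in an amine or a carboxylic acid would behave at this same ring carbon.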